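Fluoro to hydroxy at one aromatic carbon

The source may hold more compounds than are shown below. What is called first, only, known or untested is meant among the compounds shown, and "the series" means these compounds.

- Compound 1 `CN(C)Cc1cc(C(=O)/C=C/c2ccccc2)cc(CN(C)C)c1O`: 21900 nM
- Compound 2 `CN(C)Cc1cc(C(=O)/C=C/c2ccc(Cl)cc2Cl)cc(CN(C)C)c1O`: 3090 nM
- Compound 3 `CN(C)Cc1cc(C(=O)/C=C/c2ccc(F)cc2)cc(CN(C)C)c1O`: 20000 nM

All three compounds were tested in a functional assay on cells (Tumor Cell line, Homo sapiens) for cytotoxicity; a higher number here means a weaker inhibitor, a lower number a stronger inhibitor. Compound 3 gives 20000 nM and cannot be told apart from compound 1, the measured change being a 1.1-fold lower number from compound 1 to compound 3 (0.04 log units; within the scatter). Compound 2 holds the lowest number of the three.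

Compound 4 `CN(C)Cc1cc(C(=O)/C=C/c2ccc(O)cc2)cc(CN(C)C)c1O` keeps the shared core and differs from compound 3 at a single place (hydroxy in place of fluoro on an aromatic carbon). It carries hydroxy in place of fluoro on an aromatic carbon, para to a large group.

Within the data shown here, no measured compound carries hydroxy at this place, so the data give no direct reading of the change. The nearest evidence is the step from hydrogen to fluoro at the same place, a 1.1-fold lower number from compound 1 to compound 3 (0.04 log units; within the scatter), which shows that this position tolerated a single small substitution without a visible shift. Among the measured compounds shown here, both steps beyond the scatter, a 7.1-fold lower number from compound 1 to compound 2 (0.85 log units; beyond the scatter) and a 6.5-fold higher number from compound 2 to compound 3 (0.81 log units; beyond the scatter), run through compound 2, whose substituents have no counterpart in compound 4, so they bear on it only weakly.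

The expected change is small, a 1.1-fold lower number from compound 3 to compound 4 (0.05 log units; within the scatter), with no clear direction. For compound 4 the estimated value is 18000 nM, with an expected range of 7000 nM to 40000 nM.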

Compound 4, half-maximal inhibitory concentration: 39800 nM
Compound 4: middle estimate off by 2.2-fold (0.34 log units), on the low side, and the stated range covers the measured number.
By their numbers in this assay, from the lowest: compound 2; then compounds 3, 1 and 4 (each within the scatter of the next).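

The hydroxy in place of fluoro on an aromatic carbon, para to a large group, gives no change that can be read in this assay (a 2.0-fold higher number from compound 3 to compound 4 (0.30 log units; within the scatter)), and the same holds for hydroxy in place of hydrogen (a 1.8-fold higher number from compound 1 to compound 4 (0.26 log units; within the scatter)), so this place has now taken two different small groups with no shift beyond the scatter, even though the hydroxy brings a hydrogen-bond donor and acceptor that fluoro lacks. Among these compounds, the one large step involving the new compound is the change from 2,4-dichlorophenyl to 4-hydroxyphenyl (a 13-fold higher number from compound 2 to compound 4 (1.11 log units; beyond the scatter)), which shows that compound 4, like the other compounds with a single small group or none on this ring, stays well short of the low number held by the dichloro pattern. The data shown give no reason for any of these numbers.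

Going by these compounds, it remains open whether the low number of the 2,4-dichlorophenyl compound comes from the chloro at this place or from the second chloro, which a 4-chlorophenyl or a 2-chlorophenyl compound would separate. Also open, on these data alone, is how this place responds to groups larger than a single atom, such as methoxy, an amine or a carboxylic acid.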